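The source may hold more compounds than are shown below. What is called first, only, known or untested is meant among the compounds shown, and "the series" means these compounds.

Of the compounds shown here, three that share one core have been measured in an ADME assay on MT4 cells (Homo sapiens) for cytotoxicity, read by MTT assay, with a stated time of 4 days; on this read-out lower numbers stand for higher toxicity in this test and higher numbers for lower toxicity in this test. Compound 1 `N#Cc1ccc(Nc2nc(Oc3ccccc3Cl)c3ccccc3n2)cc1` gives 38000 nM, compound 2 `Cc1cccc(Oc2nc(Nc3ccc(C#N)cc3)nc3ccccc23)c1` gives 355000 nM, and compound 3 `COc1ccccc1Oc1nc(Nc2ccc(C#N)cc2)nc2ccccc12` gives 150000 nM. On these numbers compound 3 stands second highest of the three: the step of a 2.4-fold lower number from compound 2 to compound 3 (0.37 log units; beyond the scatter) separates it from compound 2, and the step of a 3.9-fold higher number from compound 1 to compound 3 (0.60 log units; beyond the scatter) separates it from compound 1. Compound 4 `N#Cc1ccc(Nc2nc(Oc3ccc(Cl)cc3Cl)c3ccccc3n2)cc1` has not yet been measured in this assay. The change from compound 3 to compound 4 is 2,4-dichlorophenyl in place of 2-methoxyphenyl on an oxygen on an aromatic ring. Within the data shown here, two measured steps bear on it. The step of a 3.9-fold higher number from compound 1 to compound 3 (0.60 log units; beyond the scatter) shows that putting methoxy in the place of chloro on that ring raised the number; the change to compound 4 runs the other way and adds a second chlorine besides. The step of a 9.3-fold higher number from compound 1 to compound 2 (0.97 log units; beyond the scatter) shows that the 3-methylphenyl ring of compound 2 gave a higher number still than the chlorinated ring of compound 1. Compound 4 is therefore expected to move back toward compound 1, which sits at 38000 nM. For compound 4 the expected step is a 6.0-fold lower number from compound 3 to compound 4 (0.78 log units; beyond the scatter), a fall beyond the scatter. The estimate for compound 4 in this assay is 25000 nM, with a range from 8000 nM to 80000 nM.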

Compound 4, half-maximal cytotoxic concentration: 32000 nM
Compound 4: middle estimate off by 1.3-fold (0.11 log units), on the low side; the measured number falls inside the stated range.
By their numbers in this assay, from the lowest: compounds 4 and 1 (each within the scatter of the next); then compound 3; then compound 2.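

In this assay, the second chlorine adds nothing that can be told apart: chloro in place of hydrogen on an aromatic carbon gives a 1.2-fold lower number from compound 1 to compound 4 (0.07 log units; within the scatter) and leaves the 2,4-dichlorophenyl ring reading like the 2-chlorophenyl ring. The rings without chlorine stay clearly apart from it, with a 4.7-fold lower number from compound 3 to compound 4 (0.67 log units; beyond the scatter) on replacing 2-methoxyphenyl and an 11-fold lower number from compound 2 to compound 4 (1.05 log units; beyond the scatter) on replacing 3-methylphenyl, the second being the largest step among these four compounds. So both chlorinated rings sit at the low end of the read-out, which here means higher toxicity in this test, no compound shown goes against that, and no measurement is available to explain it.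

The compounds shown leave open where a plain phenyl ring would fall, and so whether chlorine lowers the number or methoxy and methyl raise it. Going by these compounds, it also stays open how a ring carrying an amine or a carboxylic acid would read in this same place on the oxygen.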